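Linker shortening at the saturated ring carbon

A few compounds are considered here, and "the series" means these few. Any claim that something is new, unique, unknown or untested is made for them only; others in the source may bear on it.

Among the measured compounds shown here, in an assay on CHO cells for agonist activity at 5-hydroxytryptamine receptor 1D (Homo sapiens), read by GTPgammaS binding (a lower number here means that less compound is needed, a higher number that more compound is needed for the effect), compound 1 `c1ccc(CNCC2CCN(CCCc3c[nH]c4ccc(-n5cnnc5)cc34)CC2)cc1` gives 5.6 nM and stands second highest of the three numbers measured so far, within the scatter of both compound 2 `c1cc(CNC2CCN(CCCc3c[nH]c4ccc(-n5cnnc5)cc34)CC2)co1` at 7.1 nM and compound 3 `CC(=O)Nc1ccc(CNC2CCN(CCCc3c[nH]c4ccc(-n5cnnc5)cc34)CC2)cc1` at 5 nM. The two measured steps, a 1.3-fold higher number from compound 1 to compound 2 (0.10 log units; within the scatter) and a 1.4-fold lower number from compound 2 to compound 3 (0.15 log units; within the scatter), exchange only the group on the amine nitrogen and both stay within the scatter. Compound 4 `c1ccc(CNC2CCN(CCCc3c[nH]c4ccc(-n5cnnc5)cc34)CC2)cc1` differs from compound 1 in another way: benzylamino in place of (benzylamino)methyl on a saturated ring carbon. For the measured compounds named here, no measured step addresses this chain shortening directly, so the expectation rests on the flatness seen in this assay; the step from compound 1 to compound 4 is expected to be a 1.1-fold higher number from compound 1 to compound 4 (0.03 log units; within the scatter), none beyond the scatter. Compound 4 is therefore estimated at 6 nM, with a range from 2 nM to 18 nM.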

Compound 4, half-maximal effective concentration: 7.6 nM
Compound 4: middle estimate off by 1.3-fold (0.10 log units), on the low side; measured number inside the range.
By their numbers in this assay, from the lowest: compounds 3, 1, 2 and 4 (each within the scatter of the next).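

With the amine kept on the saturated ring carbon, the shorter benzylamino link now has a direct reading in this assay: a 1.4-fold higher number from compound 1 to compound 4 (0.13 log units; within the scatter) shows that this change stays within the scatter. Hydrogen in place of acetamido on an aromatic carbon gives a 1.5-fold higher number from compound 3 to compound 4 (0.18 log units; within the scatter) and phenyl in place of furan-3-yl gives a 1.1-fold higher number from compound 2 to compound 4 (0.03 log units; within the scatter), so neither change on the benzylamino side moves the number beyond the scatter either. No evidence on why these numbers stay so close is available.

Open, on these data alone, is whether a longer chain on the saturated ring carbon, or a carboxylic acid on the aromatic ring, would give a step beyond the scatter in this assay.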